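The compounds below may be only part of what the source reports. "The series", "measured", "known", "first", "only" and "open" are said of these compounds alone.

In an in vitro functional assay on HEK285-7 cells for antagonist activity at prostaglandin D2 receptor 2 (Homo sapiens), read by BRET and beta-arrestin recruitment (a lower number here means a smaller maximal response, a higher number a larger maximal response), compound 1 `COc1cc(-c2nc(C(c3ccc(F)cc3)c3ccc(F)cc3)sc2CC(=O)O)ccn1` gives 60%, the lower of the two numbers recorded so far. Compound 2 `O=C(O)Cc1sc(C(c2ccccc2)c2ccccc2)nc1-c1cccc(F)c1` gives 80% in this assay, a number that lies above that of compound 1 by a gap wider than the usual scatter of repeated measurements. Among the compounds with values here, no pair of measured compounds differs in only one place, so no measured step is available as a guide. Compound 3 `O=C(O)Cc1sc(C(c2ccc(F)cc2)c2ccc(F)cc2)nc1-c1ccccc1` is the next compound to be tested. It differs from compound 1 in one place: phenyl in place of 2-methoxypyridin-4-yl on an aromatic carbon. A modest rise in maximal response is expected for compound 3, a step of a number 12 percentage points higher from compound 1 to compound 3 (beyond the scatter) that may still fall within the scatter, because compound 2 reaches 80% while carrying a phenyl ring with a single fluorine at the same place. The maximal response of compound 3 is estimated at 72%, with a likely range from 55% to 90%.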

Compound 3, largest response reached (reported as efficacy), in percent of the reference or control that the assay uses: 80%
Compound 3: the middle estimate sits 8 percentage points below what was measured, and the stated range covers the measured number.
By their numbers in this assay, from the lowest: compound 1; then compounds 2 and 3 (each within the scatter of the next).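

In this assay, within the data shown here, replacing 2-methoxypyridin-4-yl with phenyl on the aromatic carbon next to the ring nitrogen gives a number 20 percentage points higher from compound 1 to compound 3 (beyond the scatter), the first measured change at a single place. The maximal response is therefore sensitive to which six-membered aromatic ring stands at this position, even though both rings are attached at the same carbon and the rest of the molecule is unchanged. Nothing available here explains this step.

The ring nitrogen and the methoxy group leave together, so the step cannot be assigned to either one alone. A plain pyridin-4-yl group or a phenyl ring carrying a methoxy group could separate the two, while an amine on the phenyl ring remains an open case.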